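The source may hold more compounds than are shown below. What is called first, only, known or untested is meant among the compounds shown, and "the series" means these compounds.

The measured compounds are compound 1 `Cc1ccc(C2(CNC(=O)Nc3c(C(C)C)cccc3C(C)C)CCCC2)cc1` with 25 nM and compound 2 `CC(C)c1cccc(C(C)C)c1NC(=O)NCC1(c2ccc([N+](=O)[O-])cc2)CCCC1` with 131 nM, both in an assay on microsomes for inhibition of acyl-CoA:cholesterol acyltransferase (Oryctolagus cuniculus); on this read-out lower numbers stand for stronger inhibition and higher numbers for weaker inhibition.

Compound 2 stands at the highest of the two numbers in this assay, with compound 1 at the lower one. Compound 3 `Cc1ccc(C2(CNC(=O)Nc3c(C(C)C)cccc3C(C)C)CCCC2)c(C)c1` differs from compound 2 in one place: 2,4-dimethylphenyl in place of 4-nitrophenyl on a saturated ring carbon. Among the measured compounds shown here, the only measured step bearing on this is a 5.2-fold higher number from compound 1 to compound 2 (0.72 log units; beyond the scatter), which runs in the opposite direction, nitro replacing methyl. Reversing it, together with the added methyl, is expected to lower the number in this assay by a 4.4-fold lower number from compound 2 to compound 3 (0.64 log units; beyond the scatter). Compound 3 is therefore expected to give about 30 nM (range 12 nM to 80 nM).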

Compound 3, half-maximal inhibitory concentration: 50 nM
Estimate against measurement, compound 3: 1.7-fold (0.22 log units) below; the range from low to high includes it.
By their numbers in this assay, from the lowest: compounds 1 and 3 (each within the scatter of the next); then compound 2.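

In this assay, the methyl added on an aromatic carbon gives a 2.0-fold higher number from compound 1 to compound 3 (0.30 log units; within the scatter), so this addition does not separate the two compounds. Moving from 4-nitrophenyl to 2,4-dimethylphenyl on the saturated ring carbon gives a 2.6-fold lower number from compound 2 to compound 3 (0.42 log units; beyond the scatter), which places the nitro compound apart from both methyl-bearing compounds. Nothing available explains either step.

From the compounds shown here alone, whether an amine, a carboxylic acid or a methoxy group in place of the nitro group would stay with the methyl-bearing compounds remains open. So does whether chlorine would serve in place of the added methyl.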